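The compounds below may be only part of what the source reports. "The series", "measured", "known", "first", "only" and "open" are said of these compounds alone.

In an ADME assay on BHK-21 cells (Mesocricetus auratus) for cytotoxicity, with a stated time of 3 days (a lower number here means that less compound is tolerated, a higher number that more compound is tolerated), compound 1 `CC(Sc1nnc(-c2ccncc2)s1)C(=O)Nc1c(Cl)cccc1Cl` gives only a limit of the assay, > 50000 nM. Compound 2 `O=C(CSc1nnc(-c2ccncc2)s1)Nc1ccc(Cl)cc1` likewise reaches only the limit, > 50000 nM. Compound 3 `O=C(CCSc1nnc(-c2ccncc2)s1)Nc1ccccc1` also stops at the limit, > 50000 nM. Going by the values given here, compound 1 thus stands at the limit of > 50000 nM in this assay, at which 3 of the 3 values shown sit, so no measured step between compounds can be read off here. Compound 4 `CC(Sc1nnc(-c2ccncc2)s1)C(=O)Nc1ccc(Cl)cc1Cl` differs from compound 1 by 2,4-dichlorophenyl in place of 2,6-dichlorophenyl on an amide-type nitrogen. Since every measured compound sits at the limit, no step beyond the usual scatter is expected from compound 1 to compound 4, and the estimated change is a number no higher from compound 1 to compound 4 (the limit leaves the size open). Compound 4 is therefore expected to give about 50000 nM, somewhere between 25000 nM and 100000 nM, most likely again only as a limit.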

Compound 4, half-maximal cytotoxic concentration: > 50000 nM
Compound 4 gave a limit, no number; the forecaster's own chance of this, stated with the estimate: 85%; the middle value lies on the limit itself.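

Compound 1 and compound 4 each stop at a limit rather than a number, so no step between them can be read: the limit of > 50000 nM in this assay, at which 4 of the 4 values shown sit.

The compounds shown leave open at what concentration any of them would become toxic to the cells in this assay.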